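Cyclohexyl to benzyl on the shared core

This account rests on a few compounds, and the source may have more. Where it says the series, first, only, none or still open, it means among the compounds named here.

In a functional assay on brain (Rattus norvegicus, strain Wistar) for inhibition (a lower number here means a stronger inhibitor, a higher number a weaker inhibitor), compound 1 `CCCCc1ccc(-c2c(C)[nH]c(=O)n2C(C)C)cc1` gives 10700 nM and compound 2 `CCCCc1ccc(-c2c(C)[nH]c(=O)n2C2CCCCC2)cc1` gives 27100 nM, the higher of the two numbers and so the weaker inhibitor. Compound 3 `CCCCc1ccc(-c2c(C)[nH]c(=O)n2Cc2ccccc2)cc1` carries benzyl in place of cyclohexyl on an aromatic nitrogen. Within the data shown here, the one measured change at this nitrogen is a 2.5-fold higher number from compound 1 to compound 2 (0.40 log units; beyond the scatter), with cyclohexyl in place of isopropyl. Among the measured compounds shown here, no measured compound carries benzyl, so the guide is loose, and only a modest move towards a lower number in this assay is expected. The expected step is a 1.5-fold lower number from compound 2 to compound 3 (0.18 log units; within the scatter). For compound 3 the estimated value is 18000 nM, within a range of 6000 nM to 50000 nM.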

Compound 3, half-maximal inhibitory concentration: 12400 nM
Beside the measured number, compound 3's estimate is 1.5-fold (0.16 log units) above it; low and high end bracket the measured number.
By their numbers in this assay, from the lowest: compounds 1 and 3 (each within the scatter of the next); then compound 2.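

In this assay there is a 2.2-fold lower number from compound 2 to compound 3 (0.34 log units; beyond the scatter), so a six-membered ring at this nitrogen need not weaken inhibition as cyclohexyl does. With a 1.2-fold higher number from compound 1 to compound 3 (0.06 log units; within the scatter), benzyl and isopropyl cannot be told apart, and cyclohexyl alone stands out among the three groups. Nothing measured here explains why benzyl and cyclohexyl differ. Still open, on these data alone, is whether a longer chain such as phenylethyl, or an amine or carboxylic acid on the benzyl ring, would change the number. Also open, as far as these compounds go, is whether any group at this nitrogen can give a clearly stronger inhibitor than isopropyl.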